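A larger group on a compound at the limit

This account rests on a few compounds, and the source may have more. Where it says the series, first, only, none or still open, it means among the compounds named here.

In a functional assay on HeLa cells (Homo sapiens) for cytotoxicity, read by MTT assay, with a stated time of 2 days (a lower number here means a stronger inhibitor, a higher number a weaker inhibitor), compound 1 `COc1cccc(-c2nc3ccc(C)cc3c(=O)[nH]2)c1` gives > 50000 nM, which is a limit and not a number. Compound 2 `Cc1ccc2nc(-c3cccc(F)c3)[nH]c(=O)c2c1` gives > 50000 nM, also a limit. Among the measured compounds shown here, the only measured change is a step that the two limits leave unreadable from compound 1 to compound 2, so it offers no size to carry forward, and the evidence is the limit of > 50000 nM in this assay, at which 2 of the 2 values shown sit. Compound 3 `Cc1ccc2nc(-c3cccc(OC(F)(F)F)c3)[nH]c(=O)c2c1` has trifluoromethoxy in place of fluoro on an aromatic carbon. No clear change in either direction is expected, and the estimated result is a number no higher from compound 2 to compound 3 (the limit leaves the size open). For compound 3 the estimated value is 50000 nM, with an expected range from 15000 nM to 100000 nM.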

Compound 3, half-maximal inhibitory concentration: > 50000 nM
Compound 3: a limit, no number; the forecaster's own chance of this, stated with the estimate: 75%; the middle value sits exactly at the limit.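

Compound 1, compound 2 and compound 3 each give only a limit, and none of the steps among them can be read. The compounds shown leave open whether any group at this place would give a readable value in this assay.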